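Notes on compound 4 in the urea-to-amide series

The source may hold more compounds than are shown below. What is called first, only, known or untested is meant among the compounds shown, and "the series" means these compounds.

Measured so far in a functional assay on MDA-MB-435 cells (Homo sapiens) for inhibition, read by sulforhodamine B assay, with a stated time of 48 h, tested at 0.01 uM; a higher number here means a weaker effect of the compound at the concentration tested, a lower number a stronger effect:
compound 1 `O=C(Nc1cccc(-n2cc(-c3ccncc3)c(-c3cc(O)cc(Cl)c3)n2)c1)Nc1ccc(Cl)c(Cl)c1`: 96%
compound 2 `COc1cc(Cl)cc(-c2nn(-c3cccc(NC(=O)Nc4cc(C(F)(F)F)cc(C(F)(F)F)c4)c3)cc2-c2ccncc2)c1`: 97%
compound 3 `COc1cc(Cl)cc(-c2nn(-c3cccc(NC(=O)Nc4ccc(Cl)c(Cl)c4)c3)cc2-c2ccncc2)c1`: 93%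

Compound 3 holds the lowest of the three numbers; its nearest neighbour is compound 1, the step of a number 3 percentage points lower from compound 1 to compound 3 (within the scatter), and compound 2 differs from it by an amount that is also within the scatter. Compound 4 `COc1cc(Cl)cc(-c2nn(-c3cccc(NC(=O)c4cccc(C(F)(F)F)c4)c3)cc2-c2ccncc2)c1` differs from compound 3 as follows: 3-(trifluoromethyl)phenyl in place of (3,4-dichlorophenyl)amino on a carbonyl carbon. Among the compounds with values here, no measured step touches the carbonyl carbon or its neighbours; the single measured step concerns methyl in place of hydrogen on an oxygen on an aromatic ring and was within the scatter. With all three numbers close to the top of the range, compound 4 is expected to stay there, the estimated step of a number 2 percentage points higher from compound 3 to compound 4 (within the scatter) being none beyond the scatter. The estimate for compound 4 is 95%, between 85% and 104%.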

Compound 4, a percentage reported as activity, at one concentration (the size of the read-out at that concentration, not a potency): 98%
The estimate for compound 4 lay 3 percentage points below the measured number; measured number inside the range.
By their numbers in this assay, from the lowest: compounds 3, 1, 2 and 4 (each within the scatter of the next).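

In this assay, the change gives a number 5 percentage points higher from compound 3 to compound 4 (within the scatter), so 3-(trifluoromethyl)phenyl can stand in place of (3,4-dichlorophenyl)amino on this carbonyl carbon without a shift beyond the scatter. Within the data shown here, this is the first step at this carbonyl carbon, and it removes the hydrogen-bond donor of the leaving group while the number stays within the scatter. Nothing available bears on why the number holds.

Still open, from the compounds shown here alone, is whether an amine or a carboxylic acid on this carbonyl carbon would move the number beyond the scatter. A longer chain between the carbonyl carbon and the aromatic ring is equally untested in the compounds shown.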